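Tetrazole in Place of Acid at the Chain End

This account rests on a few compounds, and the source may have more. Where it says the series, first, only, none or still open, it means among the compounds named here.

Compound 1 `CCc1cc(C(C)=O)c(O)cc1OCCCCCCC#N`: 73%
Compound 2 `CCc1cc(C(C)=O)c(O)cc1OCCCCCC(C)(C)C#N`: 53%
Compound 3 `CCc1cc(C(C)=O)c(O)cc1OCCCCCC(C)(C)C(=O)O`: 73%

In an assay on isolated protein for binding affinity to leukotriene B4 receptor 1 (Homo sapiens), tested at 1 uM (a higher number here means more inhibition at the concentration tested (going by the name of the read-out), a lower number less inhibition), compound 3 gives 73%, level with compound 1 and, with it, the highest of the three numbers. The step of a number 20 percentage points higher from compound 2 to compound 3 (beyond the scatter) lies beyond the scatter, whereas no change at the digits printed from compound 1 to compound 3 (within the scatter) lies within it. Compound 4 `CCc1cc(C(C)=O)c(O)cc1OCCCCCCC(C)(C)c1nnn[nH]1` differs from compound 3 in one place: 2-(1H-tetrazol-5-yl)-2-methylpropyl in place of 1-carboxy-1-methylethyl on a saturated chain carbon, five bonds along the chain from an oxygen on an aromatic ring. Within the data shown here, no measured step exchanges a carboxy for a tetrazole ring, and none extends the chain by a carbon; the only step at this end of the chain that moved the read-out is a number 20 percentage points higher from compound 2 to compound 3 (beyond the scatter). The change is therefore expected to give a step of a number 3 percentage points lower from compound 3 to compound 4 (within the scatter), inside the scatter. Compound 4 is estimated at 70%, with a range from 50% to 85%.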

Compound 4, a percentage reported as inhibition, at one concentration (the size of the read-out at that concentration, not a potency): 67%
For compound 4 the middle estimate is 3 percentage points above the measured one; low and high end bracket the measured number.
By their numbers in this assay, from the lowest: compound 2; then compounds 4, 1 and 3 (each within the scatter of the next).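

In this assay, 2-(1H-tetrazol-5-yl)-2-methylpropyl can take the place of 1-carboxy-1-methylethyl at this chain end without a clear loss (a number 6 percentage points lower from compound 3 to compound 4 (within the scatter)). The tetrazole compound also stays level with the plain nitrile (a number 6 percentage points lower from compound 1 to compound 4 (within the scatter)) and keeps a lead over the dimethyl-substituted nitrile (a number 14 percentage points higher from compound 2 to compound 4 (beyond the scatter)). No available evidence bears on why these chain ends read alike.

The change swaps the end group and also lengthens the chain, so the two contributions cannot be separated. As far as these compounds go, how a primary amide or a sulfonamide would read at this chain end stays open.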